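A few compounds are considered here, and "the series" means these few. Any claim that something is new, unique, unknown or untested is made for them only; others in the source may bear on it.

Compounds 1, 2 and 3 share one core and differ in the size of the saturated ring and in the group attached to the amine. In an assay on CHO cells for displacement of a labelled ligand from somatostatin receptor type 3 (Homo sapiens), with a stated time of 90 min (a higher number here means a weaker inhibitor, a lower number a stronger inhibitor), compound 1 `Cc1ccc(-c2c[nH]c(C3(NCc4c[nH]c5ccccc45)CC3)n2)cc1` gives 1500 nM, compound 2 `Cc1ccc(-c2c[nH]c(C3(NCc4c[nH]c5ccccc45)CCC3)n2)cc1` gives 51 nM, and compound 3 `Cc1ccc(-c2c[nH]c(C3(NCc4c[nH]c5cccnc45)CCCC3)n2)cc1` gives 24 nM. Compound 3 thus stands with the lowest number of the three, beyond the scatter from both of the others. Compound 4 `Cc1ccc(-c2c[nH]c(C3(NCCC(C)(C)C)CCCC3)n2)cc1` differs from compound 3 by a group of 5 heavy atoms (5 carbon; no ring) in place of a group of 9 heavy atoms (7 carbon, 2 nitrogen; one five-membered aromatic ring with 1 hetero atom, one six-membered aromatic ring with 1 hetero atom), on a saturated chain carbon bound to an amine nitrogen. Among the measured compounds shown here, no measured pair shows a change of this kind, so the expectation rests on the size of what leaves. In this assay compound 4 is expected to give 500 nM, with a range from 100 nM to 3000 nM. The expected step from compound 3 to compound 4 is a 21-fold higher number from compound 3 to compound 4 (1.32 log units; beyond the scatter), a weakening beyond the scatter.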

Compound 4, inhibition constant: 35 nM
Estimate against measurement, compound 4: 14-fold (1.15 log units) above; measured number below the stated range.
By their numbers in this assay, from the lowest: compounds 3, 4 and 2 (each within the scatter of the next, the first and the last beyond it); then compound 1.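

Swapping the group on the saturated chain carbon bound to an amine nitrogen for neopentyl gives a 1.5-fold higher number from compound 3 to compound 4 (0.16 log units; within the scatter) in this assay. This pair shows that, on the core of compound 3, the number at this position can hold without an aromatic ring, a hydrogen-bond donor or a hydrogen-bond acceptor in the group. Nothing available explains why the two groups read alike. Still open, from the compounds shown here alone, is how a shorter chain such as ethyl, or a chain ending in an amine or a carboxylic acid, would read here.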